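Swapping the Methoxyphenyl Arm for a Trifluoromethylphenyl

The source may hold more compounds than are shown below. What is called first, only, known or untested is meant among the compounds shown, and "the series" means these compounds.

Three compounds share one core and differ only in the aromatic group attached to it. Compound 1 `c1ccc2c(-c3cn4ccnc4c(-c4ccc5ncn(C6CCCCC6)c5c4)n3)cccc2c1` gives 16.5% in a functional assay on SNB-75 cells (Homo sapiens) for inhibition, read by sulforhodamine B assay, with a stated time of 48 h, tested at 10 uM (a lower number here means less inhibition, a higher number more inhibition at the concentration tested (going by the name of the read-out)), compound 2 `Fc1ccc(-c2cn3ccnc3c(-c3ccc4ncn(C5CCCCC5)c4c3)n2)cc1` gives 21%, and compound 3 `COc1ccccc1-c1cn2ccnc2c(-c2ccc3ncn(C4CCCCC4)c3c2)n1` gives 35%, the highest of the three: a number 18.5 percentage points higher from compound 1 to compound 3 (beyond the scatter) and a number 14 percentage points higher from compound 2 to compound 3 (beyond the scatter) both lie beyond the scatter, while a number 4.5 percentage points higher from compound 1 to compound 2 (within the scatter) does not. Compound 4 `FC(F)(F)c1cccc(-c2cn3ccnc3c(-c3ccc4ncn(C5CCCCC5)c4c3)n2)c1` changes the same place: 3-(trifluoromethyl)phenyl in place of 2-methoxyphenyl on an aromatic carbon. The two steps into compound 3 bear on this change, each a modest rise when 2-methoxyphenyl entered; the two groups without it sit close to each other. With that group gone, an expected step of a number 13 percentage points lower from compound 3 to compound 4 (beyond the scatter) follows. Compound 4 is estimated at 22%, between 8% and 36%.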

Compound 4, a percentage reported as inhibition, at one concentration (the size of the read-out at that concentration, not a potency): 4.58%
Compound 4: the middle estimate sits 17.4 percentage points above what was measured; measured number below the stated range.
By their numbers in this assay, from the lowest: compound 4; then compounds 1 and 2 (each within the scatter of the next); then compound 3.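

Changing the aromatic group at this position can do more than remove the gain seen with 2-methoxyphenyl. With 3-(trifluoromethyl)phenyl there is a number 30.4 percentage points lower from compound 3 to compound 4 (beyond the scatter), but also a number 16.4 percentage points lower from compound 2 to compound 4 (beyond the scatter) and a number 11.9 percentage points lower from compound 1 to compound 4 (beyond the scatter), so the number falls below those of the two groups without 2-methoxyphenyl as well. Nothing available explains this fall.

As far as these compounds go, it remains open whether the fall follows the trifluoromethyl group itself or where it sits on the phenyl ring. How a phenyl ring carrying an amine or a carboxylic acid would behave here is also unknown.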